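A few compounds are considered here, and "the series" means these few. Any claim that something is new, unique, unknown or untested is made for them only; others in the source may bear on it.

Working notes on the series.

In an in vitro ADME assay on microsomes from liver (Homo sapiens) for metabolic stability, tested at 1 uM (on this read-out higher numbers stand for a longer-lived compound and lower numbers for a shorter-lived compound), compound 1 `c1cn2ccnc2c(-c2ccc(N3CCCC3)nc2)n1` gives 0.233 h. Compound 2 `CN1CCC(NC(=O)c2cn3ccnc3c(N3CCN(c4ccccn4)CC3)n2)CC1` reaches the limit of this assay, with > 2 h reported as a limit rather than as a number; this is the point described by the limit of > 2 h in this assay, at which 1 of the 2 values shown sits. The two compounds share the core but differ at more than one place, so nothing is said here about the gap between them beyond what the two values show.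

Compound 3 `O=C(NC1CCNC1)c1cn2ccnc2c(N2CCN(c3ccccn3)CC2)n1` is not yet measured in this assay. Against compound 2 it carries pyrrolidin-3-yl in place of 1-methylpiperidin-4-yl on an amide-type nitrogen. Among the compounds with values here, no measured pair in this set tracks that change, so the expected step from compound 2 to compound 3, a step that the limit leaves unreadable from compound 2 to compound 3, is set at none beyond the usual scatter, as a plain expectation. Compound 3 is therefore estimated at 2.5 h in this assay, with a range from 1 h to 6 h, and a fair chance that the assay again reports only a limit.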

Compound 3, half-life: > 2 h
Compound 3 gave a limit, no number; the forecaster's own chance of this, stated with the estimate: 55%; the middle value does not contradict the limit.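

No step from compound 2 to compound 3 can be read in this assay, because both compounds are reported only as a limit: the limit of > 2 h in this assay, at which 2 of the 3 values shown sit.

The compounds shown leave open whether pyrrolidin-3-yl in place of 1-methylpiperidin-4-yl on an amide-type nitrogen changes the half-life at all.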